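This account rests on a few compounds, and the source may have more. Where it says the series, first, only, none or still open, it means among the compounds named here.

In a functional assay on SK-MEL-2 cells (Homo sapiens) for cytotoxicity, read by sulforhodamine B assay (on this read-out higher numbers stand for weaker inhibition and lower numbers for stronger inhibition), compound 1 `COCCNc1nc(-c2ccccc2)nc2ccccc12` gives 27.6 ug/mL with 2-methoxyethyl on a nitrogen on an aromatic ring, compound 2 `COC(=O)CNc1nc(-c2ccccc2)nc2ccccc12` gives 37.6 ug/mL with (methoxycarbonyl)methyl there, and compound 3 `CC(C)Nc1nc(-c2ccccc2)nc2ccccc12` gives 16.5 ug/mL with isopropyl there. Compound 3 shares the low end of these numbers with compound 1 and stands apart from compound 2 alone. Compound 4 `c1ccc(-c2nc(NC3CCCCC3)c3ccccc3n2)cc1` has not yet been measured. Its difference from compound 3 is cyclohexyl in place of isopropyl on a nitrogen on an aromatic ring in all, which is cyclohexyl in place of isopropyl on a nitrogen on an aromatic ring. Two measured steps put isopropyl at this same place: a 1.7-fold lower number from compound 1 to compound 3 (0.22 log units; within the scatter) and a 2.3-fold lower number from compound 2 to compound 3 (0.36 log units; beyond the scatter) are both small in size. In neither of them does a ring enter, so they set only a rough scale for the change and give it no direction. In this assay no step beyond the scatter is therefore expected, with a slight lean towards a lower number. The estimated step is a 1.3-fold lower number from compound 3 to compound 4 (0.10 log units; within the scatter) and nothing larger is expected. Compound 4 is expected near 13 ug/mL with an estimated range from 5.5 ug/mL to 30 ug/mL around that middle.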

Compound 4, half-maximal inhibitory concentration: 9.63 ug/mL
For compound 4 the middle estimate is 1.3-fold (0.13 log units) above the measured one; the measured number falls inside the stated range.
By their numbers in this assay, from the lowest: compounds 4, 3, 1 and 2 (each within the scatter of the next, the first and the last beyond it).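

In this assay, within the data shown here, the first group at this place to bring in a ring, cyclohexyl on a nitrogen on an aromatic ring, cannot be told apart from isopropyl (a 1.7-fold lower number from compound 3 to compound 4 (0.23 log units; within the scatter)). What is new is the separation from 2-methoxyethyl: that group lay within the scatter of isopropyl, but cyclohexyl stands clear of it (a 2.9-fold lower number from compound 1 to compound 4 (0.46 log units; beyond the scatter)) and widens the distance from (methoxycarbonyl)methyl (a 3.9-fold lower number from compound 2 to compound 4 (0.59 log units; beyond the scatter)). Among these compounds, therefore, the two groups made of carbon only both have lower numbers than the two groups that carry oxygen, although only cyclohexyl is beyond the scatter of both oxygen-bearing groups, and nothing shown here accounts for these differences.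

The compounds shown leave open whether the ring itself matters or only the number of carbons, a question that an open n-hexyl chain on the same nitrogen would address. They also leave open how a smaller cyclopropyl ring, a piperidine ring or a chain ending in a carboxylic acid would read at this place, and whether the order of the four groups would hold on another core.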